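The compounds below may be only part of what the source reports. "The series", "measured", "known", "first", "only" and "open" are said of these compounds alone.

Of the compounds shown here, three built on one shared core have been tested in a functional assay on A-431 cells (Homo sapiens) for antiproliferative activity, read by MTT assay, with a stated time of 72 h; a higher number here means a weaker inhibitor, a lower number a stronger inhibitor. Compound 1 `COc1cc2ncnc(Nc3ccc(F)c(Cl)c3)c2cc1OCCCCC(=O)Nc1ccc(S(N)(=O)=O)cc1` gives 5020 nM. Compound 2 `COc1cc2ncnc(Nc3cccc(Cl)c3)c2cc1OCCCCC(=O)Nc1ccc(S(N)(=O)=O)cc1` gives 30400 nM, and compound 3 `COc1cc2ncnc(Nc3ccc(F)cc3)c2cc1OCCCCC(=O)Nc1ccc(S(N)(=O)=O)cc1` gives 18600 nM. Compound 3 therefore stands second highest of the three numbers: its nearest neighbour is compound 2, separated by a gap within the scatter, and its furthest is compound 1, which lies beyond the scatter. The changes a 6.1-fold higher number from compound 1 to compound 2 (0.78 log units; beyond the scatter) and a 3.7-fold higher number from compound 1 to compound 3 (0.57 log units; beyond the scatter) both exceed the scatter, whereas a 1.6-fold lower number from compound 2 to compound 3 (0.21 log units; within the scatter) does not.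

Compound 4 `COc1cc2ncnc(Nc3ccc(F)c(Br)c3)c2cc1OCCCCC(=O)Nc1ccc(S(N)(=O)=O)cc1` differs from compound 3 by bromo in place of hydrogen on an aromatic carbon. The step that bears most directly on this is a 3.7-fold higher number from compound 1 to compound 3 (0.57 log units; beyond the scatter), in which a halogen left the same aromatic carbon and the number rose by a modest amount; restoring a halogen there is expected to move the number back the other way by a comparable size. In this assay compound 4 is accordingly expected to show a 4.1-fold lower number from compound 3 to compound 4 (0.62 log units; beyond the scatter). Compound 4 is estimated at 4500 nM, with a range from 1500 nM to 13000 nM.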

Compound 4, half-maximal inhibitory concentration: 8020 nM
For compound 4 the middle estimate is 1.8-fold (0.25 log units) below the measured one, and the stated range covers the measured number.
By their numbers in this assay, from the lowest: compounds 1 and 4 (each within the scatter of the next); then compounds 3 and 2 (each within the scatter of the next).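

In this assay, bromo in place of hydrogen on the aromatic carbon ortho to the fluoro group gives a 2.3-fold lower number from compound 3 to compound 4 (0.37 log units; beyond the scatter), so the lower number at this position is no longer tied to chloro alone. Bromo and chloro on this carbon cannot be told apart, with a 1.6-fold higher number from compound 1 to compound 4 (0.20 log units; within the scatter), while the 3-bromo-4-fluorophenyl group stands clear of the 3-chlorophenyl group, with a 3.8-fold lower number from compound 2 to compound 4 (0.58 log units; beyond the scatter). Nothing measured here gives a reason for these shifts.

From the compounds shown here alone, whether iodo, methyl, trifluoromethyl or a nitrile on this carbon would give a number like those of the two halogens remains open. Also open, going by these compounds, is whether the effect of bromo would hold with a shorter chain, or with a carboxylic acid in place of the sulfonamide.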